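Cyano for bromo on the naphthyl ether: cytotoxicity notes

The source may hold more compounds than are shown below. What is called first, only, known or untested is meant among the compounds shown, and "the series" means these compounds.

Measured compounds, read in an ADME assay on C8166 cells (Homo sapiens) for cytotoxicity, read by MTT assay; a higher number here means that more compound is tolerated, a lower number that less compound is tolerated:
compound 1, `Cc1cc(S(N)(=O)=O)ccc1NC(=O)COc1ccc(Cl)cc1Oc1ccc2cc(Br)ccc2c1`: 31300 nM
compound 2, `Cc1cc(S(N)(=O)=O)ccc1NC(=O)COc1ccc(F)cc1Oc1ccc2cc(Br)ccc2c1`: > 357000 nM, a limit of this assay, not a number
compound 3, `Cc1cc(S(N)(=O)=O)ccc1NC(=O)COc1ccc(F)cc1Oc1ccc2ccccc2c1Br`: 39500 nM

Compound 1 gives the lowest of the two numbers; its nearest neighbour is compound 3, and the gap between the two lies within the scatter of this assay, so no order can be read from it. The value for compound 2 is a limit only (the limit of > 357000 nM in this assay, at which 1 of the 3 values shown sits).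

The next compound, compound 4 (`Cc1cc(S(N)(=O)=O)ccc1NC(=O)COc1ccc(Cl)cc1Oc1ccc2cc(C#N)ccc2c1`), differs from compound 1 in one place: cyano in place of bromo on an aromatic carbon.

Neither measured step is this change. The step of an at least 11-fold higher number from compound 1 to compound 2 (1.05 log units; beyond the scatter) swaps one halogen for another on a different ring; the step of an at least 9.0-fold lower number from compound 2 to compound 3 (0.95 log units; beyond the scatter) moves the bromo to another position of the naphthyl ring. For the measured compounds named here, both are beyond the scatter, but neither exchanges bromo for cyano, so no step speaks to the expected direction. The expectation for compound 4 is therefore a step no larger than the scatter, a 1.1-fold higher number from compound 1 to compound 4 (0.05 log units; within the scatter), with wide uncertainty. Compound 4 is estimated at 35000 nM, between 12000 nM and 110000 nM.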

Compound 4, half-maximal cytotoxic concentration: > 383000 nM
Compound 4 gave a limit, no number; the forecaster's own chance of this, stated with the estimate: 15%; at least 10-fold (1.03 log units) between middle value and limit.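

In this assay, cyano in place of bromo, 6-bromonaphthalen-2-yl to 6-cyanonaphthalen-2-yl, gives an at least 12-fold higher number from compound 1 to compound 4 (1.08 log units; beyond the scatter). For the compounds shown here, this is the first reading of a replacement of the bromo itself: the earlier steps changed the other halogen or moved the bromo, whereas here the chloro stays and a change at this position alone takes compound 1 to a limit. The result for compound 4 is a limit and not a number: the limit of > 383000 nM in this assay, at which 1 of the 4 values shown sits.

Going by these compounds, how far the tolerated concentration of compound 4 extends therefore stays open, and the size of the step is known only from one side. Also open, on these data alone, is how this position responds to other groups, such as an amine, a carboxylic acid or a longer chain, and whether cyano reads the same with fluoro in place of chloro.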